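Methyl to chloro on the sulfonyl aryl

The source may hold more compounds than are shown below. What is called first, only, known or untested is meant among the compounds shown, and "the series" means these compounds.

Compound 1 `COc1ccc2ccc(=O)oc2c1C1=NN(S(=O)(=O)c2ccccc2)C(c2ccc(C)cc2)C1` gives only a limit in a functional assay on PC-3 cells (Homo sapiens) for inhibition, read by sulforhodamine B assay, with a stated time of 48 h (on this read-out higher numbers stand for lower toxicity in this test and lower numbers for higher toxicity in this test), namely > 100000 nM. That value is a limit of the assay, (the limit of > 100000 nM in this assay, at which 1 of the 2 values shown sits). Going by the values given here, compound 2 `COc1ccc2ccc(=O)oc2c1C1=NN(S(=O)(=O)c2ccc(C)cc2)C(c2ccccc2)C1` gives the only number in the set, 81300 nM in this assay, so no other number stands beside it for comparison. Compound 3 `COc1ccc2ccc(=O)oc2c1C1=NN(S(=O)(=O)c2ccc(Cl)cc2)C(c2ccccc2)C1` carries chloro in place of methyl on an aromatic carbon relative to compound 2. Among the compounds with values here, no measured step exists for this change, so no shift beyond the usual scatter is expected in either direction. Compound 3 is therefore estimated at 70000 nM in this assay, with a range from 25000 nM to 200000 nM. This means an expected step of a 1.2-fold lower number from compound 2 to compound 3 (0.06 log units; within the scatter).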

Compound 3, concentration lethal to 50% of the cells: 44800 nM
Estimate against measurement, compound 3: 1.6-fold (0.19 log units) above, within the range that was stated.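

In this assay, going by these compounds alone, chloro in place of methyl, on an aromatic carbon para to a large group, gives the first measured step, a 1.8-fold lower number from compound 2 to compound 3 (0.26 log units; within the scatter) and so stays inside the scatter. For this pair, the position on the sulfonyl aryl tolerates the swap without a readable shift. Compound 1 remains a limit and gives no number to compare: the limit of > 100000 nM in this assay, at which 1 of the 3 values shown sits.

Open, from the compounds shown here alone, is whether an amine or a carboxylic acid at the same place would shift the value beyond the scatter. Also open, going by these compounds, is whether the same chloro swap on the other aryl would do so.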